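Adding an amino group to a chloropurine core: expected effect

This account rests on a few compounds, and the source may have more. Where it says the series, first, only, none or still open, it means among the compounds named here.

In a functional assay on ACHN cells (Homo sapiens) for cytotoxicity, read by sulforhodamine B assay, with a stated time of 48 h (on this read-out higher numbers stand for weaker inhibition of growth and lower numbers for stronger inhibition of growth), compound 1 `ClCc1ccc(Cn2cnc3c(Cl)ncnc32)cc1` gives 310 nM, compound 2 `Nc1nc(Cl)c2ncn(Cc3ccc(CCl)cc3)c2n1` gives 9550 nM, and compound 3 `ClCc1ccccc1Cn1cnc2c(Cl)ncnc21` gives 2700 nM. Compound 3 has the same atoms as compound 1 joined differently; the difference between the two cores is not broken down here. Compound 2 arises from compound 1 by amino in place of hydrogen on an aromatic carbon, and this change made a large step, a 31-fold higher number from compound 1 to compound 2 (1.49 log units; beyond the scatter). Compound 4 `Nc1nc(Cl)c2ncn(Cc3ccccc3CCl)c2n1` is still unmeasured in this assay; it arises from compound 3 by amino in place of hydrogen on an aromatic carbon, the same change at the same place. Because the earlier step was a 31-fold higher number from compound 1 to compound 2 (1.49 log units; beyond the scatter), compound 4 is expected to show a step of similar direction and size, a 22-fold higher number from compound 3 to compound 4 (1.35 log units; beyond the scatter). Compound 4 is therefore estimated at 60000 nM in this assay, most likely between 15000 nM and 200000 nM.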

Compound 4, concentration for 50% growth inhibition: 5750 nM
Compound 4: the middle estimate sits 10-fold (1.02 log units) above what was measured; measured number below the stated range.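

In this assay the amino group gives a 2.1-fold higher number from compound 3 to compound 4 (0.33 log units; beyond the scatter), so the number rises on this core too, but by much less. The direction of the change carries over between these two cores, while its size does not: the same change on two cores in this assay, a 31-fold higher number (1.49 log units; beyond the scatter) from compound 1 to compound 2 and a 2.1-fold higher number (0.33 log units; beyond the scatter) from compound 3 to compound 4, 14-fold (1.16 log units) apart, beyond the scatter of two such steps This shows that the size of the step depends on the core it is made on, but two pairs cannot show why, or whether the direction would hold on any further core.

The compounds shown carry only hydrogen or amino at this carbon, so it stays open how a methyl, a hydroxyl or a dimethylamino group there would behave. From the compounds shown here alone, whether the two cores would also part ways for those groups is equally open.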